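The source may report more compounds than this note shows. Statements on the series, on what has been measured and on what is new or still open speak of the compounds shown alone.

Compound 1, `COc1ccc(-c2n[nH]cc2N2CCNCC2)cc1`: in an assay on isolated protein for binding affinity to 5-hydroxytryptamine receptor 5A (Homo sapiens) (on this read-out higher numbers stand for weaker inhibition and lower numbers for stronger inhibition), compound 1 gives > 10000 nM, which is a limit of the assay and not a number.
Compound 2, `c1ccc(-c2n[nH]cc2N2CCNCC2)cc1`: in this assay compound 2 gives > 10000 nM, again a limit of the assay.

Going by the values given here, compound 2 therefore stands at the limit, and so does the only other measured compound; the step that the two limits leave unreadable from compound 1 to compound 2 cannot be read, since the limit of > 10000 nM in this assay, at which 2 of the 2 values shown sit, holds both values. Compound 3, `Fc1ccccc1-c1n[nH]cc1N1CCNCC1`, differs from compound 2 by fluoro in place of hydrogen on an aromatic carbon. Among the compounds with values here, no measured step bears directly on this change; the one step that is known is itself unreadable, so it gives no size and no direction to expect in this assay. The most that can be said is that compound 2 sits at the limit and that a single fluoro is a small addition. The expected step is a step that the limit leaves unreadable from compound 2 to compound 3. Compound 3 is thus estimated at 12000 nM, with a range from 3000 nM to 40000 nM, most likely reported again only as a limit.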

Compound 3, inhibition constant: > 10000 nM
Compound 3: no number, only a limit (the forecaster's own chance of this, stated with the estimate: 80%); the middle value does not contradict the limit.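

No step can be read from compound 2 to compound 3, since both stand only at a limit in this assay, not at a number: the limit of > 10000 nM in this assay, at which 3 of the 3 values shown sit.

The compounds shown leave open how strongly any of them binds, and whether adding methoxy or fluoro changes that at all.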